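The source may report more compounds than this note shows. Statements on the series, on what has been measured and on what is new or still open speak of the compounds shown alone.

Measured in a functional assay on the whole organism for inhibition, with Rattus norvegicus as the target; on this read-out lower numbers stand for an effect already at smaller amounts and higher numbers for an effect only at larger amounts of compound:
- Compound 1 `CC(C)c1ccc(OC(Cc2ccc(C(F)(F)F)cc2)C(=O)O)cc1`: 10 mg/kg
- Compound 2 `CC(C)c1ccc(OC(CCCCCc2ccc(Cl)cc2)C(=O)O)cc1`: 10 mg/kg
- Compound 3 `CC(C)c1ccc(OC(C)(Cc2ccc(C(F)(F)F)cc2)C(=O)O)cc1`: < 5 mg/kg (a limit)

Compound 3 gives < 5 mg/kg, which is a limit of the assay and not a number. Within the data shown here, it is the only compound of the three known this way, as the limit of < 5 mg/kg in this assay, at which 1 of the 3 values shown sits, records. Compound 4 `CC(C)c1ccc(OC(C)(Cc2ccc(C(C)(C)C)cc2)C(=O)O)cc1` has tert-butyl in place of trifluoromethyl on an aromatic carbon, para to a large group (tert-butyl in place of trifluoromethyl on an aromatic carbon). Among the measured compounds shown here, no measured step makes this exchange. For the measured compounds named here, the one step that touches this series, an at least 2.0-fold lower number from compound 1 to compound 3 (0.30 log units; that floor lies within the scatter), is methyl in place of hydrogen at another place, and its floor lies within the scatter. No change beyond the scatter is therefore expected in this assay. The expected step is a number no lower from compound 3 to compound 4 (the limit leaves the size open). For compound 4 the estimate is 5 mg/kg, with an expected range from 2 mg/kg to 15 mg/kg.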

Compound 4, dose for half-maximal effect: 5 mg/kg
Estimate against measurement, compound 4: no gap at the digits printed; the measured number falls inside the stated range.
By their numbers in this assay, from the lowest: compounds 4, 1 and 2 (each within the scatter of the next).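

In this assay, tert-butyl in place of trifluoromethyl on an aromatic carbon, para to a large group, is the only exchange shown at this position, and it gives a number no lower from compound 3 to compound 4 (the limit leaves the size open). Compound 4 supplies a readable number for the methyl-bearing series, 5 mg/kg, which shows that this position accepts tert-butyl with an effect in the whole animal. Compound 3 is held only at a limit, so the size of the step stays unread: the limit of < 5 mg/kg in this assay, at which 1 of the 4 values shown sits.

As far as these compounds go, whether an amine or a nitrile at this position would give a similar number remains open. Also open, from the compounds shown here alone, is what tert-butyl gives on the chain carrying hydrogen in place of the added methyl.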